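From 4-Chlorophenyl to Phenyl on the Sulfonyl Group

The source may hold more compounds than are shown below. What is called first, only, known or untested is meant among the compounds shown, and "the series" means these compounds.

In a functional assay for inhibition, with Homo sapiens as the target (a lower number here means a stronger inhibitor, a higher number a weaker inhibitor), compound 1 (`O=C(NC[C@H](NS(=O)(=O)c1cccs1)C(=O)O)c1cc2cc(CCC3CCNCC3)sc2s1`) gives 9 nM and compound 2 (`O=C(NC[C@H](NS(=O)(=O)c1ccc(Cl)cc1)C(=O)O)c1cc2cc(CCC3CCNCC3)sc2s1`) gives 11 nM in the same test. Within the data shown here, compound 2 therefore stands level with compound 1, the only other compound measured, since the two numbers lie within the usual scatter of repeated measurements.

Compound 3 (`O=C(NC[C@H](NS(=O)(=O)c1ccccc1)C(=O)O)c1cc2cc(CCC3CCNCC3)sc2s1`) differs from compound 2 in one place: hydrogen in place of chloro on an aromatic carbon (hydrogen in place of chloro on an aromatic carbon, turning 4-chlorophenyl into phenyl). Among the measured compounds shown here, no measured step makes this exact change. The closest evidence is a 1.2-fold higher number from compound 1 to compound 2 (0.09 log units; within the scatter) (4-chlorophenyl in place of thiophen-2-yl on the same sulfonyl sulfur). That swap of one whole group for another left the number within the scatter, so one measured step is all that bears on the question. On that evidence, no step beyond the scatter is expected in this assay for the smaller change of removing the chloro. The estimated move (a 1.1-fold lower number from compound 2 to compound 3 (0.04 log units; within the scatter)) is therefore slight. Compound 3 is expected to give about 10 nM with an estimated range of 5 nM to 20 nM in this test.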

Compound 3, half-maximal inhibitory concentration: 8 nM
For compound 3 the middle estimate is 1.3-fold (0.10 log units) above the measured one; measured number inside the range.
By their numbers in this assay, from the lowest: compounds 3, 1 and 2 (each within the scatter of the next).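

In this assay, taking the chloro off the 4-chlorophenyl group removes one heavy atom and leaves phenyl on the sulfonyl sulfur. This gives the first direct reading of that single change (a 1.4-fold lower number from compound 2 to compound 3 (0.14 log units; within the scatter)), and the step stays within the scatter, so the chloro at this position is not needed to keep the number where it stands among these compounds. The other new comparison, phenyl in place of thiophen-2-yl on the same sulfur (a 1.1-fold lower number from compound 1 to compound 3 (0.05 log units; within the scatter)), also stays within the scatter, so all three groups on that sulfur read alike in this test, and no supporting data offer an explanation for this.

From the compounds shown here alone, these three compounds cover only thiophen-2-yl, phenyl and 4-chlorophenyl, so it remains open whether an amine or a methoxy group on that same aromatic carbon would also leave the number within the scatter. Going by these compounds, it is equally open whether a simple methyl group in place of the whole ring on the sulfonyl sulfur, or a change elsewhere on the shared core, would produce a step beyond the scatter.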